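The compounds below may be only part of what the source reports. "The series", "measured", "known", "first", "only" and "open" are said of these compounds alone.

Compound 1 `C=CCc1cc(-c2ccc(OC)cc2)cc(CC=C)c1O`: 69200 nM
Compound 2 `C=CCc1cc(-c2ccccc2)ccc1O`: > 100000 nM (a limit of the assay)
Compound 3 `C=CC(C)(C)c1cc(-c2ccc(OC)cc2)ccc1O`: 91000 nM

In a functional assay on HepG2 cells (Homo sapiens) for antiproliferative activity, read by MTT assay, with a stated time of 24 h (on this read-out higher numbers stand for weaker inhibition and lower numbers for stronger inhibition), compound 3 gives 91000 nM and compound 1 gives 69200 nM, two values that lie within the usual scatter of each other. Compound 2 gives only a limit, > 100000 nM. Among the compounds with values here, these are the only results available, and no pair of measured compounds differs in one place.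

Compound 4 `C=CCc1cc(-c2ccc(OC)cc2)ccc1O` has not yet been measured. It carries allyl in place of 1,1-dimethylprop-2-en-1-yl on an aromatic carbon, ortho to a hydroxy group (allyl in place of 1,1-dimethylprop-2-en-1-yl on an aromatic carbon). Compound 1 also carries allyl and gives 69200 nM, within the scatter of compound 3, so no change beyond the scatter is expected in this assay. Going by these compounds, the estimated step of a 1.1-fold lower number from compound 3 to compound 4 (0.06 log units; within the scatter) stays within the scatter, and its direction remains open. The expected value for compound 4 is 80000 nM. The estimated range for compound 4 runs from 40000 nM to 130000 nM.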

Compound 4, half-maximal inhibitory concentration: > 100000 nM
Compound 4 was reported as a limit; the forecaster's own chance of this, stated with the estimate: 30%; middle value at least 1.2-fold (0.09 log units) from the limit.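

Compound 4 is reported only as a limit of the assay, > 100000 nM in this assay. Allyl in place of 1,1-dimethylprop-2-en-1-yl on an aromatic carbon, ortho to a hydroxy group, gives an at least 1.0-fold higher number from compound 3 to compound 4 (0.04 log units; that floor lies within the scatter) and hydrogen in place of allyl on an aromatic carbon gives an at least 1.4-fold higher number from compound 1 to compound 4 (0.15 log units; that floor lies within the scatter) as the other readable step, so each change now has a floor, but neither floor clears the scatter and neither change is shown to alter the read-out. The step between compound 2 and compound 4, methoxy in place of hydrogen, cannot be read, because both values are limits: the limit of > 100000 nM in this assay, at which 2 of the 4 values shown sit.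

Going by these compounds, how far compound 4 lies past its limit remains open. Also open, on these data alone, is whether an amine or a longer chain on that aromatic carbon would give a number rather than a limit.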